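This account rests on a few compounds, and the source may have more. Where it says the series, first, only, none or still open, it means among the compounds named here.

In an ADME assay, in phosphate buffer, at 28 degrees C, at pH 7.0 (on this read-out higher numbers stand for a longer-lived compound and lower numbers for a shorter-lived compound), compound 3 `CC(C)(C)C1=C(C(=O)O)N2C(=O)[C@H]([C@@H](O)c3ccc(O)cc3)[C@H]2O1` gives 10.3 h, the second highest of three numbers. Compound 2 `CC(C)(C)OC(=O)[C@H](O)[C@H]1C(=O)N2C(C(=O)O)=C(C(C)(C)C)O[C@H]12` gives 10.7 h and compound 1 `CC(C)(C)C1=C(C(=O)O)N2C(=O)[C@H]([C@H](O)c3ccncc3)[C@H]2O1` gives 6.4 h; both lie within the scatter of compound 3. Compound 4 `CC(C)(C)C1=C(C(=O)O)N2C(=O)[C@H]([C@@H](O)CCc3ccncc3)[C@H]2O1` carries 2-(pyridin-4-yl)ethyl in place of 4-hydroxyphenyl on a saturated chain carbon bound to an oxygen on a saturated carbon and a saturated ring carbon. Among the measured compounds shown here, the only measured step at that position, a 1.0-fold lower number from compound 2 to compound 3 (0.02 log units; within the scatter), is within the scatter, so one exchange there left this assay essentially unchanged. Compound 1, which carries a pyridin-4-yl at the same place, shows a number within the scatter of compound 3 as well. The step of a 1.3-fold lower number from compound 3 to compound 4 (0.11 log units; within the scatter) is therefore expected to stay within the scatter. Compound 4 is estimated at 8 h, with a range of 4 h to 16 h.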

Compound 4, half-life: 15.8 h
Compound 4: the middle estimate sits 2.0-fold (0.30 log units) below what was measured; low and high end bracket the measured number.
By their numbers in this assay, from the lowest: compounds 1, 3, 2 and 4 (each within the scatter of the next, the first and the last beyond it).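

In this assay, two steps stay within the scatter: a 1.5-fold higher number from compound 3 to compound 4 (0.19 log units; within the scatter) and a 1.5-fold higher number from compound 2 to compound 4 (0.17 log units; within the scatter). This adds a third group, 2-(pyridin-4-yl)ethyl, to 4-hydroxyphenyl and tert-butoxycarbonyl at this place, and none of the three exchanges among them separates beyond the scatter. Nothing at hand explains why these groups read alike. Still open, going by these compounds, is whether an amine, a carboxylic acid or a longer chain at this place would move the number beyond the scatter.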